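Trading 3,5-dimethylpiperazin-1-yl for 3,3-dimethylpiperazin-1-yl

This account rests on a few compounds, and the source may have more. Where it says the series, first, only, none or still open, it means among the compounds named here.

In an ADME assay on microsomes from liver (Mus musculus) for metabolic stability, read by LC-MS, with a stated time of 10 min (a higher number here means that more of the compound is left, a lower number that less of the compound is left), compound 2 (`C[C@@H]1CN(c2cccc3c2C[C@H](CN(C)[C@H]2CCCc4cccnc42)NC3)C[C@H](C)N1`) gives 85.6% and compound 1 (`c1cnc2c(c1)CCC[C@@H]2N(CC1CC1)C[C@H]1Cc2c(cccc2N2CCNCC2)CN1`) gives 88.3% with a gap that lies within the usual scatter. Compound 3 (`CN(C[C@@H]1Cc2c(cccc2N2CCNCC2)CN1)[C@H]1CCCc2cccnc21`) stands clearly lower at 54.6% and its gap to compound 2 lies beyond the scatter.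

The next structure to consider is compound 4 (`CN(C[C@H]1Cc2c(cccc2N2CCNC(C)(C)C2)CN1)[C@H]1CCCc2cccnc21`). It carries 3,3-dimethylpiperazin-1-yl in place of the 3,5-dimethylpiperazin-1-yl of compound 2 on an aromatic carbon (3,3-dimethylpiperazin-1-yl in place of 3,5-dimethylpiperazin-1-yl on an aromatic carbon). The two compounds hold the same atoms, joined differently.

Among the measured compounds shown here, no two measured compounds differ in just one place, so no measured step can serve as a direct guide. The estimate therefore starts from compound 2 at 85.6% and allows for a slight loss. Compound 3 at 54.6% shows how far the numbers in this small set can spread, which keeps the expected range wide.

The expected change, a number 7.6 percentage points lower from compound 2 to compound 4 (within the scatter) in this assay, is a small fall that stays within the scatter. For compound 4 the estimated value is 78% with 60% as the expected lower end and 92% as the expected upper end.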

Compound 4, percent of the compound remaining: 44%
For compound 4 the middle estimate is 34 percentage points above the measured one; measured number outside the range, below it.
By their numbers in this assay, from the lowest: compound 4; then compound 3; then compounds 2 and 1 (each within the scatter of the next).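

On an aromatic carbon of the shared core, 3,3-dimethylpiperazin-1-yl in place of 3,5-dimethylpiperazin-1-yl gives a number 41.6 percentage points lower from compound 2 to compound 4 (beyond the scatter) in this assay. The two groups match in their heavy atoms, their ring and their counts of hydrogen-bond donors and acceptors, and they differ in how the atoms are joined, with defined stereocentres only in the group that leaves, so this position does not tolerate every rearrangement of the same atoms in this read-out. No measurement shown gives a reason for the fall.

On these data alone, it remains open whether the large step belongs to having both methyl groups on one ring carbon or to losing the arrangement of the 3,5-dimethylpiperazin-1-yl group, a question that a piperazine with a single methyl group or a morpholine at the same aromatic carbon could help to settle. Also open, as far as these compounds go, is whether the same exchange would give a step of similar size in a compound that carries the cyclopropylmethyl group of compound 1 on the amine nitrogen in place of the methyl group.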